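From methoxy to ethoxy on compound 1

The source may hold more compounds than are shown below. What is called first, only, known or untested is meant among the compounds shown, and "the series" means these compounds.

Measured in a functional assay on HepG2 cells (Homo sapiens) for antiproliferative activity, read by MTT assay, with a stated time of 48 h; on this read-out lower numbers stand for stronger inhibition of growth and higher numbers for weaker inhibition of growth:
Compound 1 `COC(=O)N1N=C(c2cccc(OC)c2)CC1c1cc(OC)c(OC)c(OC)c1`: 1870 nM
Compound 2 `COc1cccc(C2=NN(C(=O)OCc3ccccc3)C(c3cc(OC)c(OC)c(OC)c3)C2)c1`: > 10000 nM, a limit of the assay

Going by the values given here, compound 1 holds the only true number so far, as the entry for compound 2 is a limit and not a number.

Compound 3 `CCOc1cccc(C2=NN(C(=O)OC)C(c3cc(OC)c(OC)c(OC)c3)C2)c1` keeps the core of compound 1 and changes one group: methyl in place of hydrogen on a saturated chain carbon bound to an oxygen on an aromatic ring. This is methyl in place of hydrogen on a saturated chain carbon bound to an oxygen on an aromatic ring, which turns 3-methoxyphenyl into 3-ethoxyphenyl.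

Among the compounds with values here, the one measured step is an at least 5.3-fold higher number from compound 1 to compound 2 (0.72 log units; beyond the scatter). It puts phenyl in place of hydrogen on a saturated chain carbon bound to an oxygen next to a carbonyl group. That is a different place and a larger group, so it is only a loose guide here, though it does show that adding to compound 1 can cost growth inhibition.

A small upward drift in this assay is therefore expected, a 1.3-fold higher number from compound 1 to compound 3 (0.13 log units; within the scatter), most likely not beyond the scatter. For compound 3 the estimate is 2500 nM, with an expected range of 1000 nM to 6500 nM.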

Compound 3, concentration for 50% growth inhibition: 8360 nM
Compound 3: middle estimate off by 3.3-fold (0.52 log units), on the low side, and the stated range ends below it.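

Adding a single methyl to the 3-methoxyphenyl group of compound 1, which turns it into 3-ethoxyphenyl, weakens growth inhibition in this assay: the change gives a 4.5-fold higher number from compound 1 to compound 3 (0.65 log units; beyond the scatter). Going by these compounds alone, the only earlier step placed a larger group, a phenyl, at a different place, so this is the first sign that a group of just one heavy atom, entering on the saturated chain carbon bound to an oxygen on an aromatic ring, is enough to move the result beyond the scatter. Compound 2 stands at a limit and not at a number, so the size of its step cannot be set against this one: the limit of > 10000 nM in this assay, at which 1 of the 3 values shown sits.

The compounds shown hold only methoxy and ethoxy at this place, so it stays open whether a longer chain such as propoxy would weaken growth inhibition further, or whether a smaller hydroxy group would strengthen it. A single step also cannot tell what lies behind the rise, or whether the same methyl would weigh as heavily elsewhere on the core of compound 1.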